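The source may hold more compounds than are shown below. What is called first, only, known or untested is meant among the compounds shown, and "the series" means these compounds.

Compound 1 `CC1(c2ccccc2)CC(=O)N(CC(=O)N2CCN(c3ccc(Cl)cc3)CC2)C1=O` gives 300 mg/kg in a functional assay on the whole organism (strain CD-1) with Mus musculus as the target, with a stated time of 0.5 h; a lower number here means that less compound is needed, a higher number that more compound is needed for the effect.
Compound 2 `COc1cccc(N2CCN(C(=O)CN3C(=O)CC(C)(c4ccccc4)C3=O)CC2)c1` gives 100 mg/kg.
Compound 3 `CC1(c2ccccc2)CC(=O)N(CC(=O)N2CCN(c3ccccc3)CC2)C1=O` gives 100 mg/kg.

Compound 2 stands level with compound 3, and together they give the lowest numbers of the three; compound 1 is furthest away, as a 3.0-fold lower number from compound 1 to compound 2 (0.48 log units; beyond the scatter) shows. Compound 4 `CC1(c2ccccc2)CC(=O)N(CC(=O)N2CCN(c3ccc(Cl)c(Cl)c3)CC2)C1=O` differs from compound 2 in one place: 3,4-dichlorophenyl in place of 3-methoxyphenyl on an amine nitrogen in a ring. For the measured compounds named here, two measured steps bear on this. In this assay, a 3.0-fold lower number from compound 1 to compound 3 (0.48 log units; beyond the scatter), and a 3.0-fold lower number from compound 1 to compound 2 (0.48 log units; beyond the scatter); both steps say that a chloro on this phenyl ring went with a higher number, and compound 4 carries two chlorines there. A rise beyond the scatter is therefore expected for compound 4, a 3.0-fold higher number from compound 2 to compound 4 (0.48 log units; beyond the scatter). Compound 4 is estimated at 300 mg/kg, within 150 mg/kg to 600 mg/kg.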

Compound 4, minimum effective dose: "not active" (no number reported)
The entry for compound 4 holds no number; the estimate stays without a comparison.
By their numbers in this assay, from the lowest: compounds 2 and 3 (each within the scatter of the next); then compound 1.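

For the compounds shown here, compound 4 is reported only as "not active" in this assay, with no number, so no step from compound 2 or any other compound to compound 4 can be read. Nothing given here explains this result. The compounds shown leave open how far 3,4-dichlorophenyl shifts the dose needed.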